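The source may report more compounds than this note shows. Statements on the series, on what has been measured and on what is new or still open speak of the compounds shown alone.

Of the compounds shown here, three measured so far share one core and differ in two places. Compound 1 `CC(CS(=O)(=O)c1ccc(F)cc1)C(=O)Nc1ccc(C#N)c(C(F)(F)F)c1` gives 115000 nM in a functional assay on LNCaP cells (Homo sapiens) for antiproliferative activity, read by MTT assay, with a stated time of 96 h; on this read-out higher numbers stand for weaker inhibition and lower numbers for stronger inhibition. Compound 2 `CC(CS(=O)(=O)c1ccc(C(F)(F)F)cc1)C(=O)Nc1ccc(C#N)c(C(F)(F)F)c1` gives 58000 nM in this assay, and the step of a 2.0-fold lower number from compound 1 to compound 2 (0.30 log units; within the scatter) stays within the scatter. Compound 3 `CC(CS(=O)(=O)c1ccc(F)cc1)C(=O)Nc1ccc([N+](=O)[O-])c(C(F)(F)F)c1` gives 2670 nM in this assay, the lowest of the three numbers, reached through the large step of a 43-fold lower number from compound 1 to compound 3 (1.63 log units; beyond the scatter). Compound 4 `CC(CS(=O)(=O)c1ccc(C(F)(F)F)cc1)C(=O)Nc1ccc([N+](=O)[O-])c(C(F)(F)F)c1` has not yet been measured. The change from compound 3 to compound 4 is trifluoromethyl in place of fluoro on an aromatic carbon. For the measured compounds named here, the one measured step that bears on this swap is a 2.0-fold lower number from compound 1 to compound 2 (0.30 log units; within the scatter), made on the cyano-bearing pair, and it was within the scatter. There is no measurement of the same swap on a nitro-bearing compound. The step is therefore expected to be small, leaning if anything toward a lower number: a 1.9-fold lower number from compound 3 to compound 4 (0.28 log units; within the scatter). Compound 4 is expected to give about 1400 nM in this assay, with a range from 500 nM to 4000 nM.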

Compound 4, half-maximal inhibitory concentration: 3310 nM
For compound 4 the middle estimate is 2.4-fold (0.37 log units) below the measured one; measured number inside the range.
By their numbers in this assay, from the lowest: compounds 3 and 4 (each within the scatter of the next); then compounds 2 and 1 (each within the scatter of the next).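

Replacing 4-fluorophenyl with 4-(trifluoromethyl)phenyl has now been tested on a nitro-bearing compound, and a 1.2-fold higher number from compound 3 to compound 4 (0.09 log units; within the scatter) shows that this position is as unresponsive to the change there as it was on the cyano-bearing pair: the same change on two cores in this assay, a 2.0-fold lower number (0.30 log units; within the scatter) from compound 1 to compound 2 and a 1.2-fold higher number (0.09 log units; within the scatter) from compound 3 to compound 4, 2.5-fold (0.39 log units) apart, within the scatter of two such steps.

For the compounds shown here, the nitro-for-cyano change, until now seen only with fluoro in place, also gives a large step with trifluoromethyl in place, an 18-fold lower number from compound 2 to compound 4 (1.24 log units; beyond the scatter), and the two steps agree: the same change on two cores in this assay, a 43-fold lower number (1.63 log units; beyond the scatter) from compound 1 to compound 3 and an 18-fold lower number (1.24 log units; beyond the scatter) from compound 2 to compound 4, 2.5-fold (0.39 log units) apart, within the scatter of two such steps.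

Across these four compounds, then, the number follows the nitro or cyano group, and the choice between fluoro and trifluoromethyl barely registers.

Both groups at this position are halogen-bearing, so an amine or a carboxylic acid there could still behave differently. As far as these compounds go, whether the large drop is unique to nitro, or would also come with an amide in its place, also remains open.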